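This account rests on a few compounds, and the source may have more. Where it says the series, first, only, none or still open, it means among the compounds named here.

Compound 3 `COc1ccc(OC(C)(C)C2OCC(C/C=C\CCC(=O)O)C(c3cccnc3)O2)cc1` was tested in an assay for inhibition of prostacyclin synthase (Homo sapiens), using microsomes; on this read-out lower numbers stand for stronger inhibition and higher numbers for weaker inhibition. In this assay compound 3 gives only a limit, > 100000 nM, and no number. Compound 1 `N#Cc1ccc(C2OCC(C/C=C\CCC(=O)O)C(c3cccnc3)O2)cc1` likewise gives a limit, > 100000 nM. Compound 2 `N#Cc1ccccc1C1OCC(C/C=C\CCC(=O)O)C(c2cccnc2)O1` also gives a limit, > 100000 nM. The single one-place step among these, a step that the two limits leave unreadable from compound 1 to compound 2, cannot be read, since both ends are limits. The shared picture is the limit of > 100000 nM in this assay, at which 3 of the 3 values shown sit. Compound 4 `CC(C)(Oc1ccc(F)cc1[N+](=O)[O-])C1OCC(C/C=C\CCC(=O)O)C(c2cccnc2)O1` differs from compound 3 by 4-fluoro-2-nitrophenyl in place of 4-methoxyphenyl on an oxygen on a saturated carbon. For the measured compounds named here, no measured step bears on this change, and none of the measured compounds shows a readable value. Compound 4 is therefore expected to stay near the same limit, with the step of a number no higher from compound 3 to compound 4 (the limit leaves the size open) estimated as essentially no change. The estimate for compound 4 is 100000 nM, between 20000 nM and 300000 nM.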

Compound 4, half-maximal inhibitory concentration: 9000 nM
Compound 4: the middle estimate sits 11-fold (1.05 log units) above what was measured; measured number outside the range, below it.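

In this assay, 4-fluoro-2-nitrophenyl in place of 4-methoxyphenyl gives an at least 11-fold lower number from compound 3 to compound 4 (1.04 log units; beyond the scatter), so the aromatic ring on this oxygen can clearly change the read-out. For the compounds shown here, compound 4 has the only readable number here, and the true size of the step remains open. Compound 1, compound 2 and compound 3 each give a limit, not a number: the limit of > 100000 nM in this assay, at which 3 of the 4 values shown sit.

The compounds shown do not separate the fluoro group from the nitro group, as none carries only one of them. They also leave open what an amine on this ring would do.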